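The compounds below may be only part of what the source reports. "The series", "measured", "known", "first", "only" and "open" are said of these compounds alone.

Measured in a functional assay on HT-29 cells (Homo sapiens) for antiproliferative activity, read by sulforhodamine B assay, with a stated time of 72 h; on this read-out lower numbers stand for stronger inhibition and higher numbers for weaker inhibition:
- compound 1 `CCN1C(=O)CS/C1=N/Nc1nncc2ccccc12`: 58 nM
- compound 2 `Cc1cc(C)nc(NS(=O)(=O)c2ccc(Nc3nncc4ccccc34)cc2)n1`: 3.3 nM

Compound 2, at 3.3 nM, holds the lower of the two numbers. Compound 1 gives 58 nM, and this gap lies beyond the usual scatter. The two compounds differ in more than one place, so this gap says nothing about any single change.

Compound 3 `O=S(=O)(Nc1nccs1)c1ccc(Nc2nncc3ccccc23)cc1` has not yet been measured. It keeps the rest of compound 2 and carries 1,3-thiazol-2-yl in place of 4,6-dimethylpyrimidin-2-yl on a sulfonamide nitrogen.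

Among the compounds with values here, no measured pair shows this change, so the expectation has little to rest on. The low number of compound 2, 3.3 nM, leaves more room for a rise than for a fall, and a small rise toward weaker inhibition is the likelier outcome. In this assay the expected move is a 1.8-fold higher number from compound 2 to compound 3 (0.26 log units; within the scatter), which may not clear the scatter. For compound 3 the estimated value is 6 nM, with an expected range of 1.5 nM to 25 nM.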

Compound 3, half-maximal inhibitory concentration: 34 nM
Beside the measured number, compound 3's estimate is 5.7-fold (0.75 log units) below it; the whole stated range lies below it.
By their numbers in this assay, from the lowest: compound 2; then compounds 3 and 1 (each within the scatter of the next).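

In this assay, within the data shown here, the substituent on the sulfonamide nitrogen proves able to shift the read-out: 1,3-thiazol-2-yl in place of 4,6-dimethylpyrimidin-2-yl gives a 10-fold higher number from compound 2 to compound 3 (1.01 log units; beyond the scatter), the only single-place step available and a large one. The entering group has one five-membered aromatic ring and 5 heavy atoms, and the leaving group has one six-membered aromatic ring and 8 heavy atoms, while the hydrogen-bond donor and acceptor counts are the same in both, so those counts do not track this step. No measurement at hand bears on the reason for the step.

On these data alone, with one step at this position, it remains open whether ring size, the two methyl groups or the identity of the ring hetero atoms accounts for the change. As far as these compounds go, a pyrimidin-2-yl without the methyl groups or a plain phenyl on the sulfonamide nitrogen would help separate these parts, and the effect of the same change on other cell lines also remains open.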